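The compounds below may be only part of what the source reports. "The series", "measured", "known", "first", "only" and "open" are said of these compounds alone.

Working notes on the series. In a functional assay, with a stated time of 10 min (on this read-out higher numbers stand for weaker inhibition and lower numbers for stronger inhibition), compound 1 (`CCOc1cc(OC)c(Br)cc1C(C)=O`) gives 57700000 nM, compound 2 (`CCCCOc1cc(OC)c(Br)cc1C(C)=O`) gives 56900000 nM and compound 3 (`CCCCCCCCOc1cc(OC)c(Br)cc1C(C)=O`) gives 38100000 nM. Compound 3 stands within the scatter of both other compounds, so the three numbers set up no order.

Compound 4 (`CCCCCCCCCCCCOc1cc(OC)c(Br)cc1C(C)=O`) differs from compound 3 by butyl in place of hydrogen on a saturated chain carbon, eight bonds along the chain from an oxygen on an aromatic ring.

Within the data shown here, three measured steps bear on this change. The closest is a 1.5-fold lower number from compound 2 to compound 3 (0.17 log units; within the scatter), the same butyl entering four bonds along the chain. The others are a 1.0-fold lower number from compound 1 to compound 2 (0.01 log units; within the scatter) and a 1.5-fold lower number from compound 1 to compound 3 (0.18 log units; within the scatter). All three stay within the scatter, so no step beyond the scatter is expected in this assay, though no measured chain runs this far.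

The expected step is a 1.1-fold lower number from compound 3 to compound 4 (0.04 log units; within the scatter). For compound 4 the estimated value is 35000000 nM, with an expected range of 17000000 nM to 70000000 nM.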

Compound 4, half-maximal inhibitory concentration: 23100000 nM
For compound 4 the middle estimate is 1.5-fold (0.18 log units) above the measured one; the measured number falls inside the stated range.
By their numbers in this assay, from the lowest: compounds 4, 3, 2 and 1 (each within the scatter of the next, the first and the last beyond it).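

In this assay the butyl entering eight bonds along the chain gives a 1.6-fold lower number from compound 3 to compound 4 (0.22 log units; within the scatter) and so stays within the scatter, as the same butyl did four bonds along the chain. The octyl entering four bonds along the chain gives a 2.5-fold lower number from compound 2 to compound 4 (0.39 log units; beyond the scatter) and is the first step shown for this chain to pass the scatter, though only modestly, so a difference appears here only over the larger change and not over the single butyl step. Nothing measured here accounts for this step.

As far as these compounds go, whether a longer chain than that of compound 4 would move the number further remains open. Also open is how an amine or a carboxylic acid carried on the chain would compare with the plain saturated chains shown.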